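A few compounds are considered here, and "the series" means these few. Any claim that something is new, unique, unknown or untested is made for them only; others in the source may bear on it.

Compound 1 `O=C1C[C@H]2O[C@H]([C@H](O)c3ccccc3)[C@H](O)[C@H]2O1` is the starting point for this step. In a functional assay on HL-60 cells (Homo sapiens) for antiproliferative activity, read by MTT assay, with a stated time of 72 h (on this read-out higher numbers stand for weaker inhibition and lower numbers for stronger inhibition), compound 1 gives > 100000 nM, which is a limit of the assay and not a number, as recorded in the limit of > 100000 nM in this assay, at which 1 of the 2 values shown sits. Among the compounds with values here, compound 2 `O=C1C[C@H]2O[C@H]([C@H](OC(=O)c3ccccc3)c3ccccc3)[C@H](O)[C@H]2O1` carries benzoyl in place of hydrogen on an oxygen on a saturated carbon; in this assay compound 2 gives 120 nM, and the step of an at least 830-fold lower number from compound 1 to compound 2 (2.92 log units; beyond the scatter) is the only measured step in the set. Compound 3 `O=C1C[C@H]2O[C@H](Cc3ccccc3)[C@H](O)[C@H]2O1` differs from compound 1 by hydrogen in place of hydroxy on a saturated chain carbon bound to an aromatic carbon and a saturated ring carbon. The measured step to compound 2 removes the free hydroxy while adding benzoyl, whereas the change to compound 3 removes the hydroxy and adds nothing, so the measured step bears on it only in part. Compound 1 sits at the limit, so the expected step for compound 3 is an at least 1.6-fold lower number from compound 1 to compound 3 (0.22 log units; that floor lies within the scatter), a modest gain at most. Compound 3 is estimated at 60000 nM, in the range 8000 nM to 300000 nM.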

Compound 3, half-maximal inhibitory concentration: 43800 nM
The estimate for compound 3 lay 1.4-fold (0.14 log units) above the measured number, and the stated range covers the measured number.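

Replacing the hydroxy on the saturated chain carbon bound to an aromatic carbon and a saturated ring carbon with hydrogen, adding nothing in its place, gives an at least 2.2-fold lower number from compound 1 to compound 3 (0.35 log units; beyond the scatter) in this assay. This step is only a floor, because the value for compound 1 is a limit and not a number: the limit of > 100000 nM in this assay, at which 1 of the 3 values shown sits.

Loss of the hydroxy alone leaves compound 3 at 43800 nM, whereas compound 2, with benzoyl on that oxygen, gives 120 nM, so removing the free hydroxy does not by itself reach the level of compound 2.

Open, as far as these compounds go, is whether a smaller acyl group such as acetyl on that oxygen would come close to benzoyl. Also open, from the compounds shown here alone, is how an amine in place of the hydroxy on this carbon would read in this assay.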